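An iodo group on compound 3

A few compounds are considered here, and "the series" means these few. Any claim that something is new, unique, unknown or untested is made for them only; others in the source may bear on it.

Among the compounds with values here, in a functional assay on HeLa cells (Homo sapiens) for antiproliferative activity, with a stated time of 48 h (a lower number here means a stronger inhibitor, a higher number a weaker inhibitor), compound 3 `Nc1ccc(/C=C/C(=O)c2ccccc2)cc1` gives the highest of the three numbers so far (36000 nM), against compound 1 `C=C(Br)C(=O)Nc1ccc(/C=C/C(=O)c2ccccc2)cc1` (3900 nM) and compound 2 `C=C(Br)C(=O)Nc1ccc(/C=C/C(=O)c2cccc3ccccc23)cc1` (2000 nM). Compound 4 `Nc1ccc(/C=C/C(=O)c2ccc(I)cc2)cc1` has iodo in place of hydrogen on an aromatic carbon. Within the data shown here, the one measured step (a 9.2-fold higher number from compound 1 to compound 3 (0.97 log units; beyond the scatter)) lies at the nitrogen and not at this place, so it bears only indirectly. Compound 1 and compound 2 differ in the part of the molecule that takes the iodo, yet their values lie within the usual scatter of each other. A small move towards a lower number is therefore expected (estimated a 2.0-fold lower number from compound 3 to compound 4 (0.30 log units; within the scatter)). Compound 4 is expected at 18000 nM (estimated range 6000 nM to 50000 nM).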

Compound 4, half-maximal inhibitory concentration: 58000 nM
The estimate for compound 4 lay 3.2-fold (0.51 log units) below the measured number, and the stated range ends below it.
By their numbers in this assay, from the lowest: compounds 2 and 1 (each within the scatter of the next); then compounds 3 and 4 (each within the scatter of the next).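

In this assay, iodo in place of hydrogen on an aromatic carbon, para to a large group, gives a step within the scatter (a 1.6-fold higher number from compound 3 to compound 4 (0.21 log units; within the scatter)). This position on the shared core therefore tolerates a single iodine with no measurable gain, whereas the change at the nitrogen lies beyond the scatter (a 9.2-fold higher number from compound 1 to compound 3 (0.97 log units; beyond the scatter)). Nothing available bears on why this is so. Going by these compounds, whether a methoxy or hydroxyl group at this place would read differently stays open. So does whether iodo behaves alike when the nitrogen carries (1-bromoethenyl)carbonyl, as in compound 1.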